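Benzylic aryl exchange: thiophene to pyridine in compound 3

A few compounds are considered here, and "the series" means these few. Any claim that something is new, unique, unknown or untested is made for them only; others in the source may bear on it.

Among the compounds with values here, compound 2 `Cc1cc(Cc2cccs2)c(=O)n(CC(=O)Nc2ccc(Br)cc2)n1` in an assay on HL-60 cells for agonist activity at N-formyl peptide receptor 3 (Homo sapiens), read by calcium flux (on this read-out lower numbers stand for an effect already at smaller amounts and higher numbers for an effect only at larger amounts of compound), gives 10200 nM, the only number in the set so far. Compound 1 `Cc1cc(Cc2cccc(Br)c2)c(=O)n(CC(=O)Nc2ccc(Br)cc2)n1` gives > 50000 nM, a limit of this assay and not a number (the limit of > 50000 nM in this assay, at which 1 of the 2 values shown sits). Within the data shown here, the single measured step, an at least 4.9-fold lower number from compound 1 to compound 2 (0.69 log units; beyond the scatter), concerns the same place as the change now followed but a different aryl group. Compound 3 `Cc1cc(Cc2cccnc2)c(=O)n(CC(=O)Nc2ccc(Br)cc2)n1` differs from compound 2 by pyridin-3-yl in place of thiophen-2-yl on a saturated chain carbon bound to an aromatic carbon. Among the measured compounds shown here, no measured step covers this replacement, so the step of a 1.2-fold higher number from compound 2 to compound 3 (0.07 log units; within the scatter) expected for compound 3 is set near zero, in neither direction beyond the scatter. Compound 3 is therefore estimated at 12000 nM, with a wide range from 3000 nM to 50000 nM.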

Compound 3, half-maximal effective concentration: > 50000 nM
Compound 3 gave a limit, no number (the forecaster's own chance of this, stated with the estimate: 30%); middle value at least 4.1-fold (0.61 log units) away from the limit.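

At this place, on a saturated chain carbon bound to an aromatic carbon, pyridin-3-yl does not retain the response that thiophen-2-yl gives in this assay, with an at least 4.9-fold higher number from compound 2 to compound 3 (0.69 log units; beyond the scatter). Of the three aryl groups shown, only thiophen-2-yl gives a number, so any reading at this place rests on compound 2 alone: the limit of > 50000 nM in this assay, at which 2 of the 3 values shown sit. The step from compound 1 to compound 3 cannot be read, as both values are limits.

Still open, as far as these compounds go, is whether the change follows the six-membered ring or the ring nitrogen; unsubstituted phenyl or furan-2-yl at this place would separate the two. Also open, from the compounds shown here alone, is whether any group here gives a lower number than compound 2.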